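The source may hold more compounds than are shown below. What is called first, only, known or untested is meant among the compounds shown, and "the series" means these compounds.

Measured in a functional assay on MDA-MB-231 cells (Homo sapiens) for inhibition, read by MTT assay, with a stated time of 48 h; on this read-out lower numbers stand for stronger inhibition of growth and higher numbers for weaker inhibition of growth:
- compound 1 `Cc1cccc(Nc2ncnc3ccc(NC(=S)NCc4ccccc4)cc23)c1C`: 28700 nM
- compound 2 `CCc1cccc(Nc2ncnc3ccc(NC(=S)NCc4ccccc4)cc23)c1`: 10500 nM

Compound 1 has the higher of the two numbers, so it is the weaker growth inhibitor of this pair. Compound 3 `CC(C)c1ccc(Nc2ncnc3ccc(NC(=S)NCc4ccccc4)cc23)cc1` has not yet been measured. It keeps the core of compound 1 but carries 4-isopropylphenyl in place of 2,3-dimethylphenyl on a nitrogen on an aromatic ring.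

For the measured compounds named here, only one measured step bears on this change. That step is a 2.7-fold lower number from compound 1 to compound 2 (0.44 log units; beyond the scatter), where 3-ethylphenyl replaces the same 2,3-dimethylphenyl at the same place. It is modest, and it is a single pair. Going by the values given here, no measured compound carries 4-isopropylphenyl, so the comparison is only a loose guide. A lower number of similar size is therefore expected in this assay, although a result within the scatter of compound 1 would not be surprising. The estimated change is a 2.2-fold lower number from compound 1 to compound 3 (0.34 log units; beyond the scatter). For compound 3 the expected value is 13000 nM, with an estimated range from 5500 nM to 30000 nM.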

Compound 3, concentration for 50% growth inhibition: 12800 nM
The estimate for compound 3 lay 1.0-fold (0.01 log units) above the measured number; the range from low to high includes it.
By their numbers in this assay, from the lowest: compounds 2 and 3 (each within the scatter of the next); then compound 1.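

In this assay, the lower number is no longer tied to 3-ethylphenyl: with 4-isopropylphenyl on the same nitrogen, the change from 2,3-dimethylphenyl gives a 2.2-fold lower number from compound 1 to compound 3 (0.35 log units; beyond the scatter) and is again beyond the scatter. The two replacement groups are not separated, since the comparison gives a 1.2-fold higher number from compound 2 to compound 3 (0.09 log units; within the scatter) and lies within the scatter, so this assay does not distinguish 3-ethylphenyl from 4-isopropylphenyl at this position. Nothing available explains why 2,3-dimethylphenyl stands apart from these two groups.

All three groups on this nitrogen are phenyl rings bearing only hydrocarbon substituents, so the compounds leave open how a ring carrying a methoxy group, a chlorine atom or an amine would read in this assay. Because the substituent pattern and the group itself differ together in these pairs, they also cannot show whether a single methyl group, a longer chain or an unsubstituted phenyl would fall with compound 2 and compound 3 or with compound 1.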